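Pyridyl to methylpyrazolyl on the amide nitrogen of compound 3

The source may hold more compounds than are shown below. What is called first, only, known or untested is meant among the compounds shown, and "the series" means these compounds.

Measured so far in an assay on HEK293 cells for agonist activity at transient receptor potential cation channel subfamily M member 8 (Homo sapiens), read by fluorescence and calcium flux, with a stated time of 15 min; on this read-out lower numbers stand for an effect already at smaller amounts and higher numbers for an effect only at larger amounts of compound:
compound 1, `Cc1ccc(OCC(=O)N(Cc2cccs2)C2CCCCC2)cc1`, gives 40000 nM
compound 2, `Cc1ccc(OCC(=O)N(Cc2cccs2)C2COC2)cc1`, gives 23000 nM
compound 3, `Cc1ccc(OCC(=O)N(Cc2cccs2)c2ccncc2)cc1`, gives 52 nM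

Compound 3 stands lowest of the three numbers in this assay. Its nearest neighbour is compound 2, and the step from there is large: a 440-fold lower number from compound 2 to compound 3 (2.65 log units; beyond the scatter). The step from compound 1 is larger still: a 770-fold lower number from compound 1 to compound 3 (2.89 log units; beyond the scatter). Between compound 1 and compound 2 the difference is small: a 1.7-fold lower number from compound 1 to compound 2 (0.24 log units; within the scatter).

Compound 4, `Cc1ccc(OCC(=O)N(Cc2cccs2)c2cnn(C)c2)cc1`, has not been measured. It differs from compound 3 in one place: 1-methyl-1H-pyrazol-4-yl in place of pyridin-4-yl on an amide-type nitrogen. Among the compounds with values here, no measured step swaps one aromatic ring for another on this nitrogen; the two large steps both replaced a ring without aromatic character by pyridin-4-yl, so they bear on the new step only in showing that this position is sensitive. The ring entering compound 4 is, like the one it replaces, aromatic, so a step of that size in either direction is not expected. A modest loss is expected, roughly an estimated 2.9-fold higher number from compound 3 to compound 4 (0.46 log units; beyond the scatter), with wide uncertainty. For compound 4 the estimate in this assay is 150 nM, in a range of 40 nM to 800 nM.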

Compound 4, half-maximal effective concentration: 63000 nM
For compound 4 the middle estimate is 420-fold (2.62 log units) below the measured one, outside the stated range (above it).
By their numbers in this assay, from the lowest: compound 3; then compounds 2, 1 and 4 (each within the scatter of the next, the first and the last beyond it).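

In this assay, within the data shown here, the earlier compounds showed only that pyridin-4-yl on this amide-type nitrogen stood far from two rings without aromatic character, and a 1200-fold higher number from compound 3 to compound 4 (3.08 log units; beyond the scatter) now shows that an aromatic ring there does not by itself carry that low number. The 1-methyl-1H-pyrazol-4-yl group instead leaves compound 4 in the range of the non-aromatic compounds, with a 2.7-fold higher number from compound 2 to compound 4 (0.44 log units; beyond the scatter) as a modest step and a 1.6-fold higher number from compound 1 to compound 4 (0.20 log units; within the scatter) as a step within the scatter, so among the four groups shown only pyridin-4-yl gives a low number in this assay. Nothing at hand accounts for the gap between the two aromatic rings, which differ in ring size, in the count of hetero atoms and in the methyl group.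

The compounds shown leave open which of these differences matters, since 1H-pyrazol-4-yl without the methyl group could separate the methyl from the ring itself. They also leave open whether pyridin-3-yl or plain phenyl on this nitrogen would stay near compound 3 or fall toward compound 4.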